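Adding a Hydroxy Group to a Dibromobenzamide Without Measured Activity

A few compounds are considered here, and "the series" means these few. Any claim that something is new, unique, unknown or untested is made for them only; others in the source may bear on it.

Measured so far, all in an assay on isolated protein for inhibition of thiosulfate sulfurtransferase (Homo sapiens), with a stated time of 60 min, in the absence of a further agent; a lower number here means a stronger inhibitor, a higher number a weaker inhibitor:
- compound 1 `O=C(Nc1ccccc1)c1cc(Br)cc(Br)c1` gives only the limit > 100000 nM
- compound 2 `O=C(Nc1ccc(Sc2nc3ccccc3s2)c(Cl)c1)c1cc(Br)cc(Br)c1` gives only the limit > 100000 nM
- compound 3 `O=C(Nc1ccc(Sc2nc3ccccc3s2)cc1)c1cc(Br)cc(Br)c1` gives only the limit > 100000 nM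

Compound 2 therefore has no number of its own in this assay, only a limit, and it shares this position with the two other measured compounds, as shown by the limit of > 100000 nM in this assay, at which 3 of the 3 values shown sit. The change under consideration is hydroxy in place of hydrogen on an aromatic carbon, giving compound 4 `O=C(Nc1ccc(Sc2nc3ccccc3s2)c(Cl)c1)c1cc(Br)cc(Br)c1O`; cut one bond further out, 3,5-dibromophenyl becomes 3,5-dibromo-2-hydroxyphenyl. For the measured compounds named here, the single measured step, a step that the two limits leave unreadable from compound 2 to compound 3, cannot be read in size or direction, and no measured step involves a hydroxy group at all. The data thus offer no basis to expect a shift beyond the scatter in this assay in either direction. Compound 4 is estimated at 100000 nM, within 15000 nM to 300000 nM, most probably again reported only as a limit. The step of a number no higher from compound 2 to compound 4 (the limit leaves the size open) is accordingly expected to be small.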

Compound 4, half-maximal inhibitory concentration: > 100000 nM
Compound 4 gave a limit, no number; the forecaster's own chance of this, stated with the estimate: 60%; the middle value sits exactly at the limit.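

Compound 2 and compound 4 both give only a limit, and the step between them cannot be read. The same holds for every compound shown: the limit of > 100000 nM in this assay, at which 4 of the 4 values shown sit. The compounds shown leave open whether hydroxy in place of hydrogen alters inhibition at all, and which structure would give an actual number in this assay.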